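Methyl in place of cyano on selenium: series notes

The source may report more compounds than this note shows. Statements on the series, on what has been measured and on what is new or still open speak of the compounds shown alone.

Measured so far in a functional assay on RKO cells (Homo sapiens) for inhibition, read by MTT assay, with a stated time of 48 h; a lower number here means a stronger inhibitor, a higher number a weaker inhibitor:
compound 1 `COc1ccc(N(C)c2nc(C)nc3ccccc23)cc1[Se]C`, 11 nM
compound 2 `Cc1nc(N(C)c2ccc([Se]C#N)c(Cl)c2)c2ccccc2n1`, 11 nM
compound 3 `COc1ccc(N(C)c2nc(C)nc3ccccc23)cc1[Se]C#N`, 47 nM

Compound 3 and compound 1 differ in one place, (methyl in place of cyano on a selenium), and that change gives a 4.3-fold lower number from compound 3 to compound 1 (0.63 log units; beyond the scatter). Compound 2 carries a different core from compound 3; the difference between the two cores is not broken down here. In this assay compound 2 and compound 1 stand level at the digits read, and both sit furthest from compound 3.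

Compound 4 `C[Se]c1ccc(N(C)c2nc(C)nc3ccccc23)cc1Cl` is not yet measured. Among the compounds with values here, it differs from compound 2 by methyl in place of cyano on a selenium, the same change, at the same kind of place, as the one from compound 3 to compound 1. Because that earlier change gave a 4.3-fold lower number from compound 3 to compound 1 (0.63 log units; beyond the scatter), a step of about a 2.8-fold lower number from compound 2 to compound 4 (0.44 log units; beyond the scatter) is expected from compound 2 to compound 4, tempered somewhat since the change has been seen only once and on another core. Compound 4 is therefore estimated at 4 nM, with the expected range 1.5 nM to 12 nM.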

Compound 4, half-maximal inhibitory concentration: 4 nM
Estimate against measurement, compound 4: no gap at the digits printed; measured number inside the range.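

Methyl in place of cyano on a selenium gives a 2.8-fold lower number from compound 2 to compound 4 (0.44 log units; beyond the scatter) in this assay and so lowers the number here as well. The change therefore carries from the core of compound 3 to the core of compound 2 in direction, and the two steps do not separate in size: the same change on two cores in this assay, a 4.3-fold lower number (0.63 log units; beyond the scatter) from compound 3 to compound 1 and a 2.8-fold lower number (0.44 log units; beyond the scatter) from compound 2 to compound 4, 1.6-fold (0.19 log units) apart, within the scatter of two such steps. This rests on two pairs on two cores, so it supports transfer between these cores only, and it shows neither why the step arises nor that it would hold on a further core.

The compounds shown leave open whether a longer chain on the selenium, such as ethyl or propyl, or a chain ending in an amine or a carboxylic acid, would follow methyl or cyano in this assay series. Also open, as far as these compounds go, is whether the same step would appear with fluoro in place of the chloro of compound 4.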